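The source may hold more compounds than are shown below. What is called first, only, known or untested is meant among the compounds shown, and "the series" means these compounds.

Working notes on the series.

The shared core carries a secondary amine linked to a benzylic group that varies across the set. Compound 1 `O=c1cc(CNCc2ccccc2[N+](=O)[O-])oc2ccc(O)c(O)c12` gives 41300 nM in an ADME assay on Huh-7 cells (Homo sapiens) for cytotoxicity; on this read-out higher numbers stand for lower toxicity in this test and lower numbers for higher toxicity in this test. Compound 2 `Cc1ccccc1CNCc1cc(=O)c2c(O)c(O)ccc2o1` gives 52200 nM in this assay. For compound 3 `O=c1cc(CNCc2cccc(F)c2)oc2ccc(O)c(O)c12` the value in this assay is a limit of the assay, > 100000 nM, and not a number. Among the two numbers given, compound 2 is separated from compound 1 only by a 1.3-fold higher number from compound 1 to compound 2 (0.10 log units; within the scatter), which is within the scatter, so no order between them is claimed. The step from compound 2 to compound 3 shows an at least 1.9-fold higher number from compound 2 to compound 3 (0.28 log units; that floor lies within the scatter); its size is open because compound 3 sits at the limit of > 100000 nM in this assay, at which 1 of the 3 values shown sits.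

Compound 4 `O=c1cc(CNCc2cccc(O)c2)oc2ccc(O)c(O)c12` differs from compound 2 by 3-hydroxyphenyl in place of 2-methylphenyl on a saturated chain carbon bound to an amine nitrogen. Both steps that touch the benzylic group, a 1.3-fold higher number from compound 1 to compound 2 (0.10 log units; within the scatter) and an at least 1.9-fold higher number from compound 2 to compound 3 (0.28 log units; that floor lies within the scatter), stay within the scatter, so no movement beyond the scatter is expected in this assay; the expected step is a 1.4-fold higher number from compound 2 to compound 4 (0.16 log units; within the scatter). Compound 4 is therefore estimated at 75000 nM, with a range from 35000 nM to 150000 nM, and a real chance that only a limit is reported, as for compound 3.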

Compound 4, half-maximal cytotoxic concentration: > 100000 nM
Compound 4 was reported as a limit (the forecaster's own chance of this, stated with the estimate: 40%); middle value at least 1.3-fold (0.12 log units) from the limit.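

In this assay, 3-hydroxyphenyl in place of 2-methylphenyl on a saturated chain carbon bound to an amine nitrogen gives an at least 1.9-fold higher number from compound 2 to compound 4 (0.28 log units; that floor lies within the scatter), so only a floor can be read for this change, as with 3-fluorophenyl. The value of compound 4 is a limit of the assay, and this position now holds a second group whose value is a limit and not a number: the limit of > 100000 nM in this assay, at which 2 of the 4 values shown sit. The step from compound 3 to compound 4, hydroxy in place of fluoro on an aromatic carbon, cannot be read, so no order between these two compounds is claimed.

How far the true values of compound 3 and compound 4 lie from compound 2 stays open, so a step beyond the scatter is neither shown nor excluded. Also open, from the compounds shown here alone, is how an amine or a carboxylic acid on the phenyl ring, or a longer chain to that ring, would read in this assay.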